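From vinyl to but-1-en-1-yl on compound 3

This account rests on a few compounds, and the source may have more. Where it says the series, first, only, none or still open, it means among the compounds named here.

In a functional assay on A549 cells (Homo sapiens) for antiproliferative activity, read by MTT assay, with a stated time of 72 h (on this read-out higher numbers stand for weaker inhibition and lower numbers for stronger inhibition), compound 3 (`C=CC(=O)Nc1cccc(Oc2nc(Nc3ccc(OC)cc3)nc3c2CSCC3)c1`) gives 4220 nM and holds the lowest number of the three measured compounds, with its gaps to both others beyond the scatter. The change under consideration is but-1-en-1-yl in place of vinyl on a carbonyl carbon and leads to compound 4 (`CC/C=C/C(=O)Nc1cccc(Oc2nc(Nc3ccc(OC)cc3)nc3c2CSCC3)c1`), which otherwise keeps the structure of compound 3. Going by the values given here, no measured step makes this change directly. Among the compounds with values here, the only measured step, a 1.7-fold lower number from compound 1 to compound 2 (0.23 log units; within the scatter) for cyano in place of methoxy on an aromatic carbon, concerns another part of the molecule and offers no guide to size. The indirect evidence comes from two compounds that already carry but-1-en-1-yl: compound 1 (`CC/C=C/C(=O)Nc1cccc(Oc2nc(Nc3cccc(OC)c3)nc3c2CSCC3)c1`) at 17200 nM and compound 2 (`CC/C=C/C(=O)Nc1cccc(Oc2nc(Nc3cccc(C#N)c3)nc3c2CSCC3)c1`) at 10100 nM both stand higher than compound 3. Both also differ from compound 3 elsewhere, so this evidence is only suggestive. The expected change is therefore a move to a higher number, estimated as a 2.3-fold higher number from compound 3 to compound 4 (0.35 log units; beyond the scatter) in this assay overall. Compound 4 is expected at 9500 nM with an estimated range from 4000 nM to 22000 nM in this reading.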

Compound 4, half-maximal inhibitory concentration: 20100 nM
Estimate against measurement, compound 4: 2.1-fold (0.33 log units) below; low and high end bracket the measured number.
By their numbers in this assay, from the lowest: compound 3; then compounds 2, 1 and 4 (each within the scatter of the next).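

In this assay, but-1-en-1-yl in place of vinyl on the carbonyl carbon gives a 4.8-fold higher number from compound 3 to compound 4 (0.68 log units; beyond the scatter), a direct reading of this change with 4-methoxyphenyl held fixed on the nitrogen, and one beyond the scatter. With but-1-en-1-yl in place, the group on the nitrogen shows no effect beyond the scatter: 4-methoxyphenyl in place of 3-cyanophenyl gives a 2.0-fold higher number from compound 2 to compound 4 (0.30 log units; within the scatter), and 4-methoxyphenyl in place of 3-methoxyphenyl gives a 1.2-fold higher number from compound 1 to compound 4 (0.07 log units; within the scatter). No measurement shown here explains the step at the carbonyl carbon.

On these data alone, whether vinyl gives a lower number than but-1-en-1-yl with 3-cyanophenyl or 3-methoxyphenyl on the nitrogen remains open. Also open, as far as these compounds go, is how an ethyl group, or a but-1-en-1-yl chain ending in a dimethylamine, would read on the same carbonyl carbon.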